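Aryl carbamate in place of the dienyl ether

The source may report more compounds than this note shows. Statements on the series, on what has been measured and on what is new or still open speak of the compounds shown alone.

Measured so far in a functional assay on PANC-1 cells (Homo sapiens) for inhibition, read by MTT assay, with a stated time of 24 h, tested at 10 uM; a higher number here means more inhibition at the concentration tested (going by the name of the read-out), a lower number less inhibition:
compound 1 `CC(C)=CCC/C(C)=C/COc1cc(=O)n(CCCO)c2c1CC(CC=C(C)C)C(C)(C)C2` gives 10.6%
compound 2 `CC(C)=CCC1Cc2c(OC(=O)Nc3ccc(F)c(Cl)c3)cc(=O)n(CCCO)c2CC1(C)C` gives 79.8%
compound 3 `CC(C)=CCC/C(C)=C/COc1cc(=O)n(CCCO)c2c1CC(C/C=C(\C)CCC=C(C)C)C(C)(C)C2` gives 15.8%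

Compound 3 stands second highest of the three numbers. The step of a number 5.2 percentage points higher from compound 1 to compound 3 (within the scatter) is within the scatter, so compound 3 and compound 1 cannot be told apart; compound 2 stands well beyond both.

Compound 4 `CC(C)=CCC/C(C)=C/CC1Cc2c(OC(=O)Nc3ccc(Cl)c(Cl)c3)cc(=O)n(CCCO)c2CC1(C)C` differs from compound 3 by (3,4-dichlorophenyl)carbamoyl in place of 3,7-dimethylocta-2,6-dien-1-yl on an oxygen on an aromatic ring. Among the compounds with values here, the one measured step that bears on this is a number 69.2 percentage points higher from compound 1 to compound 2 (beyond the scatter), where a carbamoyl group likewise entered in place of 3,7-dimethylocta-2,6-dien-1-yl on the oxygen on the aromatic ring. Compound 2 is the only carbamate measured, so the comparison rests on one pair. An upward step of comparable size is therefore expected, a number 62.2 percentage points higher from compound 3 to compound 4 (beyond the scatter). Compound 4 is estimated at 78%, in the range 60% to 92%.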

Compound 4, a percentage reported as inhibition, at one concentration (the size of the read-out at that concentration, not a potency): 20%
Beside the measured number, compound 4's estimate is 58 percentage points above it, and the stated range ends above it.
By their numbers in this assay, from the lowest: compounds 1, 3 and 4 (each within the scatter of the next); then compound 2.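

In this assay the carbamate exchange on this oxygen brings no general gain: with the 3,7-dimethylocta-2,6-dien-1-yl chain kept on the core, it gives a number 4.2 percentage points higher from compound 3 to compound 4 (within the scatter), against a number 69.2 percentage points higher from compound 1 to compound 2 (beyond the scatter) with the 3-methylbut-2-en-1-yl chain and a (3-chloro-4-fluorophenyl)carbamoyl group. A (3,4-dichlorophenyl)carbamoyl group on this oxygen is therefore not enough by itself to raise the number. No measurement here explains why the two exchanges part.

Still open, as far as these compounds go, is whether the other chain or the aryl halogen decides the outcome. Also open, from the compounds shown here alone, is how an unsubstituted phenylcarbamoyl group reads at this oxygen.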